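Halogen swap on the pendant aryl ring of compound 3

This account rests on a few compounds, and the source may have more. Where it says the series, first, only, none or still open, it means among the compounds named here.

Compound 3 `O=CCN1N=C(c2ccc3ccccc3c2)CC1c1cccc(Cl)c1Cl` stands second highest of the three numbers in a functional assay on OVCAR cells (Homo sapiens) for cytotoxicity, read by sulforhodamine B assay, with a stated time of 48 h (on this read-out higher numbers stand for weaker inhibition and lower numbers for stronger inhibition), giving 15100 nM. Compound 1 `O=CCN1N=C(c2ccc3ccccc3c2)CC1c1ccccc1` gives 21500 nM, and compound 2 `O=CCN1N=C(c2ccc3ccccc3c2)CC1c1cccc([N+](=O)[O-])c1` gives 3390 nM. Compound 4 `O=CCN1N=C(c2ccc3ccccc3c2)CC1c1cccc(Br)c1` differs from compound 3 by 3-bromophenyl in place of 2,3-dichlorophenyl on a saturated ring carbon. The nearest measured steps are a 1.4-fold lower number from compound 1 to compound 3 (0.15 log units; within the scatter) and a 4.5-fold higher number from compound 2 to compound 3 (0.65 log units; beyond the scatter), with a 6.3-fold lower number from compound 1 to compound 2 (0.80 log units; beyond the scatter) showing the nitro effect. Within the data shown here, no step with bromine on this ring is available, so the change is read against the phenyl and dichlorophenyl cases, which sit within the scatter of each other. A small shift, if any, is therefore expected in this assay, as a 1.3-fold lower number from compound 3 to compound 4 (0.10 log units; within the scatter). Compound 4 is estimated at 12000 nM, within 4000 nM to 32000 nM.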

Compound 4, half-maximal inhibitory concentration: 10800 nM
Estimate against measurement, compound 4: 1.1-fold (0.05 log units) above, within the range that was stated.
By their numbers in this assay, from the lowest: compound 2; then compounds 4, 3 and 1 (each within the scatter of the next).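

In this assay, the 3-bromophenyl of compound 4 cannot be separated from the 2,3-dichlorophenyl (a 1.4-fold lower number from compound 3 to compound 4 (0.15 log units; within the scatter)) or from the unsubstituted phenyl (a 2.0-fold lower number from compound 1 to compound 4 (0.30 log units; within the scatter)), so neither halogen pattern stands apart from hydrogen on this ring. The nitro case remains the one that stands apart, now also against bromine, with a 3.2-fold higher number from compound 2 to compound 4 (0.50 log units; beyond the scatter) for bromo in place of nitro. No measurement available here explains these steps.

Open, going by these compounds, is whether an amine or a carboxylic acid on this ring would read with compound 2 or with the halogen compounds. Also open, on these data alone, is how a single chlorine would compare with the bromine of compound 4.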